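This account rests on a few compounds, and the source may have more. Where it says the series, first, only, none or still open, it means among the compounds named here.

Working notes on the series, all read in a functional assay on HeLa cells (Homo sapiens) for inhibition, read by sulforhodamine B assay, with a stated time of 74 h; a higher number here means a weaker inhibitor, a lower number a stronger inhibitor. Compound 1 `O=C1C=CC2(C=C1)OCC(=O)N2S(=O)(=O)c1ccccc1` gives > 10000 nM, which is a limit and not a number. Among the compounds with values here, compound 2 `Cc1ccccc1S(=O)(=O)N1C(=O)COC12C=CC(=O)C=C2` gives 3720 nM, the one true number so far. Compound 3 `O=C1C=CC2(C=C1)OCC(=O)N2S(=O)(=O)c1ccc([N+](=O)[O-])cc1` gives > 10000 nM, again a limit. This places compound 3 at the limit of > 10000 nM in this assay, at which 2 of the 3 values shown sit.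

Compound 4 `O=C1C=CC2(C=C1)OCC(=O)N2S(=O)(=O)c1ccc(N2CCCC2=O)cc1` follows from compound 3 by a single change, 2-oxopyrrolidin-1-yl in place of nitro on an aromatic carbon, para to a large group: 2-oxopyrrolidin-1-yl in place of nitro on an aromatic carbon.

Within the data shown here, two measured steps bear on it. Methyl in place of hydrogen on an aromatic carbon gave an at least 2.6-fold lower number from compound 1 to compound 2 (0.42 log units; beyond the scatter). Adding a nitro group to the aromatic ring instead gave a step that the two limits leave unreadable from compound 1 to compound 3. Neither step replaces nitro, so the size of this one cannot be read directly. Compound 2 at 3720 nM shows only that a substituent on this aromatic ring can bring a readable number. A modest move to a lower number is therefore expected, with wide uncertainty, and the expected step is an at least 1.6-fold lower number from compound 3 to compound 4 (0.22 log units; that floor lies within the scatter). For compound 4 the estimated value is 6000 nM, with an expected range of 1500 nM to 20000 nM.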

Compound 4, half-maximal inhibitory concentration: 880 nM
For compound 4 the middle estimate is 6.8-fold (0.83 log units) above the measured one; measured number below the stated range.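

In this assay, 2-oxopyrrolidin-1-yl in place of nitro gives an at least 11-fold lower number from compound 3 to compound 4 (1.05 log units; beyond the scatter), and the same group in place of hydrogen gives an at least 11-fold lower number from compound 1 to compound 4 (1.05 log units; beyond the scatter). This aromatic carbon, para to a large group, can therefore carry a substituent that gives a readable number, which nitro there does not. Both steps are floors and their true size is unknown, because each starts from a limit and not a number: the limit of > 10000 nM in this assay, at which 2 of the 4 values shown sit.

The compounds shown do not separate the contribution of the five-membered non-aromatic ring from that of its carbonyl, and an open-chain acetamide or a simple amine at this same aromatic carbon would bear on that question. Going by these compounds, whether a larger lactam ring or a carboxylic acid there would give a lower or a higher number also stays open.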